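Series notes: methoxy for dimethylamino on the benzyl arm

The compounds below may be only part of what the source reports. "The series", "measured", "known", "first", "only" and "open" are said of these compounds alone.

The series is followed in a physicochemical assay for acid dissociation. Three compounds are measured. Compound 1 `CN(Cc1ccc(N(C)C)cc1)Cc1ccccc1CNc1ccnc2cc(Cl)ccc12` gives 7.4 in this assay. Compound 2 `COc1ccc(CN(C)Cc2ccc(CNc3ccnc4cc(Cl)ccc34)cc2)cc1` gives 7.44 in this assay. Compound 3 `CN(Cc1ccc(CNc2ccnc3cc(Cl)ccc23)cc1)Cc1ccc(N(C)C)cc1` gives 7.33 in this assay. The values of compound 1, compound 2 and compound 3 all lie within the scatter of one another, so no order among them can be stated. Compound 1 and compound 3 have the same atoms joined differently; the difference between the two cores is not broken down here.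

One structural change is made in two pairs. From compound 3 to compound 2 the change is methoxy in place of dimethylamino on an aromatic carbon, and it moved the number as a number 0.11 log units higher from compound 3 to compound 2 (within the scatter). The same change is now made from compound 1 to compound 4 `COc1ccc(CN(C)Cc2ccccc2CNc2ccnc3cc(Cl)ccc23)cc1`, not yet measured: methoxy in place of dimethylamino on an aromatic carbon. The two place descriptions read the same word for word, so the change is taken as the same change set on a different core.

The expectation for compound 4 rests on the earlier pair: the step from compound 3 to compound 2 stayed within the scatter, so the step from compound 1 to compound 4 is expected to be of a similar size, a number 0.10 log units higher from compound 1 to compound 4 (within the scatter). For compound 4 the estimated value in this assay is 7.5, expected to fall between 7.2 and 7.8.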

Compound 4, acid dissociation constant: 7.47
Compound 4: the middle estimate sits 0.03 log units above what was measured, within the range that was stated.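

In this assay the change of methoxy in place of dimethylamino on an aromatic carbon gives a number 0.07 log units higher from compound 1 to compound 4 (within the scatter) on one core and a number 0.11 log units higher from compound 3 to compound 2 (within the scatter) on the other, and both steps are printed as within the scatter. Across these two pairs, then, the change leaves no readable mark on either core, and the two cores agree in that plain sense, though neither step gives the change a direction that could be said to carry over. This does not show that the change is neutral in general or on any further core, since only these two pairs stand behind the reading, and nothing measured here says why the number holds as it does, so no explanation is offered.

The compounds shown leave open whether another group on the same aromatic carbon, such as a carboxylic acid, a primary amine or a trifluoromethyl, would also stay within the scatter on both cores. They also leave open whether a read-out other than this assay would respond to methoxy and dimethylamino in the same way on the two cores.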